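The source may report more compounds than this note shows. Statements on the series, on what has been measured and on what is new or still open speak of the compounds shown alone.

Measured so far in an ADME assay on Vero cells (Chlorocebus sabaeus) for cytotoxicity; on this read-out higher numbers stand for lower toxicity in this test and lower numbers for higher toxicity in this test:
Compound 1, `Fc1ccc(-c2nc3cc(C(F)(F)F)ccc3[nH]2)cc1`, gives 60000 nM.
Compound 2, `CC(=O)Nc1ccc(-c2nc3ccccc3[nH]2)cc1`, stops at the assay limit of > 100000 nM.
Compound 3, `Fc1cccc(F)c1-c1nc2cc(Cl)c(Cl)cc2[nH]1`, likewise stops at the assay limit of > 100000 nM.

Among the results shown, compound 1 carries the only actual number; the other two results are limits rather than numbers, since (the limit of > 100000 nM in this assay, at which 2 of the 3 values shown sit). Within the data shown here, no two measured compounds differ in just one place, so no measured step is available to guide the next change. Compound 4, `O=[N+]([O-])c1ccc(-c2nc3cc(C(F)(F)F)ccc3[nH]2)cc1`, has not yet been tested. It differs from compound 1 by nitro in place of fluoro on an aromatic carbon. Among the measured compounds shown here, with no measured step to lean on, the expected step in this assay is none beyond the usual scatter, that is no change at the digits printed from compound 1 to compound 4 (within the scatter). Compound 4 is therefore expected to give about 60000 nM, somewhere between 20000 nM and 200000 nM, with a fair chance that only a limit is reported.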

Compound 4, half-maximal cytotoxic concentration: 45000 nM
Compound 4: middle estimate off by 1.3-fold (0.12 log units), on the high side, within the range that was stated.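

In this assay, nitro in place of fluoro on this aromatic carbon, para to a large group, gives a 1.3-fold lower number from compound 1 to compound 4 (0.12 log units; within the scatter). This first readable step shows that exchanging one heavy atom for three, two hydrogen-bond acceptors among what enters, moves the number no further than repeat measurements would. Compound 2 and compound 3 give limits, not numbers, and offer no such step: the limit of > 100000 nM in this assay, at which 2 of the 4 values shown sit.

Going by these compounds, whether an amine or a carboxylic acid at this position would shift the number stays open. So does the role of the trifluoromethyl group elsewhere on the core.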